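The source may hold more compounds than are shown below. What is called first, only, known or untested is meant among the compounds shown, and "the series" means these compounds.

In an ADME assay on MT4 cells (Homo sapiens) for cytotoxicity, read by MTT assay (on this read-out lower numbers stand for higher toxicity in this test and higher numbers for lower toxicity in this test), three compounds have been tested, and all three return limits rather than numbers. Compound 1 `O=C(CSc1nc(Cc2c(Cl)cccc2Cl)cc(=O)[nH]1)c1ccc(F)cc1` gives > 59000 nM as a limit. Compound 2 `O=C(CSc1nc(Cc2c(F)cccc2Cl)cc(=O)[nH]1)c1ccc(F)cc1`, the starting point here, gives > 61000 nM as a limit. Compound 3 `COc1ccc(C(=O)CSc2nc(Cc3c(F)cccc3Cl)cc(=O)[nH]2)cc1` gives > 12000 nM as a limit. The change to compound 4 `CCC(C)c1c(Cc2c(F)cccc2Cl)nc(SCC(=O)c2ccc(F)cc2)[nH]c1=O` puts sec-butyl in place of hydrogen on an aromatic carbon, counted as sec-butyl in place of hydrogen on an aromatic carbon here. The nearest measured steps are a step that the two limits leave unreadable from compound 1 to compound 2 and a step that the two limits leave unreadable from compound 2 to compound 3 and neither touches this carbon. Neither gives a size to carry over, so in this assay only a loose expectation is possible, leaning toward lower numbers. The expected step is an at least 2.0-fold lower number from compound 2 to compound 4 (0.30 log units; that floor lies within the scatter) as a rough estimate. For compound 4 the estimate is 30000 nM within an expected range from 6000 nM to 90000 nM in this test.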

Compound 4, half-maximal cytotoxic concentration: > 54000 nM
Compound 4: a limit, no number; the forecaster's own chance of this, stated with the estimate: 60%; middle value at least 1.8-fold (0.25 log units) from the limit.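

Compound 2 and compound 4 both give limits rather than numbers in this assay, so no step can be read between them. The compounds shown leave open whether sec-butyl in place of hydrogen shifts this read-out at all.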